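This account rests on a few compounds, and the source may have more. Where it says the series, first, only, none or still open, it means among the compounds named here.

The measured compounds:
compound 1, `Cc1ccc([C@@H](C)Oc2cc3oc(=O)n(CCC(=O)O)c3cc2Cl)nc1`, 3.16 nM
compound 2, `O=C(O)CCn1c(=O)oc2cc(OCC3CCC3)c(Cl)cc21`, 25.1 nM
compound 3, `CC(C)Cc1cc2oc(=O)n(CCC(=O)O)c2cc1Cl`, 12.6 nM

In an assay for inhibition of kynurenine 3-monooxygenase (Homo sapiens), read by mass spectrometry, with a stated time of 1 h (a lower number here means a stronger inhibitor, a higher number a weaker inhibitor), compound 2 gives the highest of the three numbers. Its nearest neighbour is compound 3, which gives 12.6 nM; the step of a 2.0-fold lower number from compound 2 to compound 3 (0.30 log units; within the scatter) lies within the scatter, so the two cannot be told apart. Compound 1, which gives 3.16 nM, stands furthest away, beyond the scatter.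

Compound 4, `O=C(O)CCn1c(=O)oc2cc(OCC3CC3)c(Cl)cc21`, has not yet been measured. It differs from compound 2 by cyclopropyl in place of cyclobutyl on a saturated chain carbon bound to an oxygen on an aromatic ring.

Among the measured compounds shown here, only one measured step touches this position: a 2.0-fold lower number from compound 2 to compound 3 (0.30 log units; within the scatter), in which an isobutyl took the place of the whole cyclobutylmethoxy, and even that left the number within the scatter. For the measured compounds named here, no measured pair sets a cyclobutyl against a cyclopropyl, so the direction of the move from compound 2 to compound 4 cannot be read from the data. Because a 2.0-fold lower number from compound 2 to compound 3 (0.30 log units; within the scatter) stayed within the scatter with a larger swap at this position, the step of a 1.2-fold higher number from compound 2 to compound 4 (0.08 log units; within the scatter) is expected to be no larger. For compound 4 the estimate in this assay is 30 nM, with a range from 12 nM to 80 nM.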

Compound 4, half-maximal inhibitory concentration: 10 nM
The estimate for compound 4 lay 3.0-fold (0.48 log units) above the measured number, and the stated range ends above it.
By their numbers in this assay, from the lowest: compound 1; then compounds 4, 3 and 2 (each within the scatter of the next, the first and the last beyond it).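

In this assay, among the compounds shown here, the step of a 2.5-fold lower number from compound 2 to compound 4 (0.40 log units; beyond the scatter) is the first measured comparison of two ring sizes at this position. It is modest, but unlike the step of a 2.0-fold lower number from compound 2 to compound 3 (0.30 log units; within the scatter) it lies beyond the scatter, so here a change as small as cyclopropyl in place of cyclobutyl on a saturated chain carbon bound to an oxygen on an aromatic ring can be told apart in this assay. The step of a 1.3-fold lower number from compound 3 to compound 4 (0.10 log units; within the scatter) stays within the scatter, so cyclopropylmethoxy and isobutyl on an aromatic carbon cannot be separated here, and nothing measured accounts for the difference between cyclobutyl and cyclopropyl.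

Going by these compounds, two ring sizes make a single comparison and not a trend, so it remains open whether the number depends on ring size in any regular way. A cyclopentyl or a tert-butyl on the same saturated chain carbon would show whether the number keeps moving in the same direction or the cyclopropyl result stands alone.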